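A few compounds are considered here, and "the series" means these few. Any claim that something is new, unique, unknown or untested is made for them only; others in the source may bear on it.

Compound 1 `Nc1cc(N)c2nc(-c3ccccc3)c(NCc3ccc(Cl)c(Cl)c3)nc2c1` is one of two measured compounds in a functional assay on A549 cells (Homo sapiens) for inhibition, read by sulforhodamine B assay, with a stated time of 48 h (on this read-out higher numbers stand for weaker inhibition of growth and lower numbers for stronger inhibition of growth), where compound 1 gives 10700 nM. The other, compound 2 `Nc1cc(N)c2nc(-c3ccccc3)c(Sc3ccc(F)cc3)nc2c1`, gives in this assay 13500 nM. Compound 1 holds the smaller of the two numbers, but its gap to compound 2 lies within the scatter of repeated measurements, so the two cannot be separated on this read-out.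

Compound 3 `COc1ccc(CNc2nc3cc(N)cc(N)c3nc2-c2ccccc2)cc1` has not yet been measured. It differs from compound 1 in a single place: 4-methoxyphenyl in place of 3,4-dichlorophenyl on a saturated chain carbon bound to a nitrogen on an aromatic ring. Going by the values given here, no step between measured compounds touches the same position, so there is nothing to show how large such a change tends to be here. With only that to go on, a modest shift is expected, and the step from compound 1 to compound 3 is estimated as a 1.1-fold higher number from compound 1 to compound 3 (0.05 log units; within the scatter), a change that may well stay within the scatter. For compound 3 the expected value in this assay is 12000 nM, within a range from 4000 nM to 40000 nM.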

Compound 3, concentration for 50% growth inhibition: 21400 nM
Beside the measured number, compound 3's estimate is 1.8-fold (0.25 log units) below it; measured number inside the range.
By their numbers in this assay, from the lowest: compounds 1, 2 and 3 (each within the scatter of the next).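

Going by these compounds alone, this is the first step that touches this position: in this assay, 4-methoxyphenyl in place of 3,4-dichlorophenyl on a saturated chain carbon bound to a nitrogen on an aromatic ring gives a 2.0-fold higher number from compound 1 to compound 3 (0.30 log units; within the scatter) and so does not separate the two compounds. The exchange loses both chlorine atoms and brings in an oxygen with one hydrogen-bond acceptor, yet this pair shows no change beyond the scatter on this read-out. No measured evidence is at hand to explain this outcome.

The compounds shown leave open how this position would respond to an unsubstituted benzyl, a 4-chlorobenzyl or a longer chain such as 2-phenylethyl. They also leave open whether an amine or a carboxylic acid on the phenyl ring would move the number beyond the scatter.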